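Benzamido-thiazole chalcones: thiophene at the styryl terminus

A few compounds are considered here, and "the series" means these few. Any claim that something is new, unique, unknown or untested is made for them only; others in the source may bear on it.

Measured so far:
compound 1, `Cc1nc(NC(=O)c2ccccc2)sc1C(=O)/C=C/c1ccc(Br)cc1`: 52.3%
compound 2, `COc1ccc(/C=C/C(=O)c2sc(NC(=O)c3ccccc3)nc2C)cc1`: 58.8%

In an assay for inhibition of Polyunsaturated fatty acid 5-lipoxygenase (Homo sapiens), read by spectrophotometry, tested at 10 uM, in the presence of a further agent that is not named here (on this read-out higher numbers stand for more inhibition at the one concentration tested (going by the name of the read-out) and lower numbers for less inhibition), compound 1 gives 52.3% and compound 2 gives 58.8%. Among the measured compounds shown here, compound 2 carries the larger of the two numbers, but the sole measured step, a number 6.5 percentage points higher from compound 1 to compound 2 (within the scatter), stays within the scatter, so the two compounds cannot be told apart on this read-out.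

Compound 3, `Cc1nc(NC(=O)c2ccccc2)sc1C(=O)/C=C/c1cccs1`, is not yet measured. Its change from compound 2 is thiophen-2-yl in place of 4-methoxyphenyl on a double-bonded chain carbon bound to a double-bonded chain carbon. For the measured compounds named here, no measured step bears directly on this change: the step from compound 1 to compound 2 only exchanged one substituent on an aromatic carbon and kept the six-membered ring, whereas here the whole 4-methoxyphenyl gives way to thiophen-2-yl. With both measured numbers close together and no step beyond the scatter anywhere in the series, the expectation for compound 3 is a number near the measured pair, with no step beyond the scatter, a number 5.8 percentage points lower from compound 2 to compound 3 (within the scatter). Compound 3 is therefore estimated at 53%, with a range from 30% to 75%.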

Compound 3, a percentage reported as inhibition, at one concentration (the size of the read-out at that concentration, not a potency): 71.9%
For compound 3 the middle estimate is 18.9 percentage points below the measured one; low and high end bracket the measured number.
By their numbers in this assay, from the lowest: compounds 1 and 2 (each within the scatter of the next); then compound 3.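

In this assay, the ring on a double-bonded chain carbon bound to a double-bonded chain carbon proves able to move the read-out: thiophen-2-yl in place of 4-methoxyphenyl gives a number 13.1 percentage points higher from compound 2 to compound 3 (beyond the scatter) and thiophen-2-yl in place of 4-bromophenyl gives a number 19.6 percentage points higher from compound 1 to compound 3 (beyond the scatter) as the second modest gain in the series. Exchanging only the substituent on the six-membered ring had stayed within the scatter, so among these compounds only replacing the whole ring separates one compound from another. Nothing measured here accounts for the gain.

Still open, on these data alone, is whether the gain belongs to the sulfur, to the five-membered ring or to the loss of the para-free phenyl arrangement as a whole, which a furan-2-yl or thiophen-3-yl at this place would begin to separate. Also open, as far as these compounds go, is whether a methyl group on the thiophene keeps the gain.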